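Amino in Place of Hydroxy and Cytotoxicity

The compounds below may be only part of what the source reports. "The series", "measured", "known", "first", "only" and "open" are said of these compounds alone.

Measured compounds:
compound 1 `Oc1ccc(-c2cccc(O)c2)cc1`: 31 ug/mL
compound 2 `Nc1cccc(-c2ccc(O)cc2)c1`: > 100 ug/mL
compound 3 `COc1ccc(-c2cccc(O)c2)cc1OC`: 23.1 ug/mL

In an ADME assay on HEK293 cells (Homo sapiens) for cytotoxicity, read by MTT assay, with a stated time of 3 days (a lower number here means a stronger inhibitor, a higher number a weaker inhibitor), compound 1 gives 31 ug/mL. Compound 2 reaches only a limit of the assay, > 100 ug/mL. The change from compound 1 to compound 2 is amino in place of hydroxy on an aromatic carbon and gave an at least 3.2-fold higher number from compound 1 to compound 2 (0.50 log units; beyond the scatter). Compound 3 gives 23.1 ug/mL in this assay; how the core of compound 3 differs from the core of compound 1 is not broken down here.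

Compound 4 `COc1ccc(-c2cccc(N)c2)cc1OC` has not yet been measured. It differs from compound 3 by amino in place of hydroxy on an aromatic carbon, the same kind of change as that from compound 1 to compound 2, though the place here is described as meta to a large group rather than meta to a group of 7 heavy atoms. The step from compound 3 to compound 4 is expected to be a 4.3-fold higher number from compound 3 to compound 4 (0.64 log units; beyond the scatter), resting on the earlier at least 3.2-fold higher number from compound 1 to compound 2 (0.50 log units; beyond the scatter). Compound 4 is therefore estimated at 100 ug/mL, between 45 ug/mL and 300 ug/mL, most likely again only a limit.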

Compound 4, half-maximal inhibitory concentration: 20 ug/mL
Compound 4: the middle estimate sits 5.0-fold (0.70 log units) above what was measured, outside the stated range (below it).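

In this assay, amino in place of hydroxy on an aromatic carbon gave a 1.2-fold lower number from compound 3 to compound 4 (0.06 log units; within the scatter), so the higher number seen with the same change on the core of compound 1 did not carry over to the core of compound 3. The two steps differ by more than the scatter of such steps: the same change on two cores in this assay, an at least 3.2-fold higher number (0.50 log units; beyond the scatter) from compound 1 to compound 2 and a 1.2-fold lower number (0.06 log units; within the scatter) from compound 3 to compound 4, at least 3.7-fold (0.57 log units) apart, beyond the scatter of two such steps. What in the two cores separates these outcomes is not shown, and compound 2 stands at a limit of the assay, so the full size of the earlier step is not known: the limit of > 100 ug/mL in this assay, at which 1 of the 4 values shown sits.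

The compounds shown leave open how other groups at this place, such as a carboxylic acid or an amide, would read in this assay. They also leave open whether such groups would differ between the two cores as amino does.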